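The source may report more compounds than this note shows. Statements on the series, on what has been measured and on what is new or still open speak of the compounds shown alone.

Series notes. Three compounds of one core are measured: compound 1 `Cc1nc2c(OCc3ccccc3)cccn2c1CCC#N`, compound 2 `CCOCc1c(C)nc2c(OCc3ccccc3)cccn12` and compound 3 `Cc1nc2c(OCc3ccccc3)cccn2c1C[S+](C)[O-]`. In a functional assay on the whole organism (stomach) for inhibition, with Canis familiaris (Canis lupus familiaris) as the target, at a dose of 5 mg/kg by the intravenous route (on this read-out lower numbers stand for a weaker effect and higher numbers for a stronger effect at the one dose given), compound 1 gives 20%, compound 2 gives 35% and compound 3 gives 18%. Compound 2 stands highest of the three numbers: a number 15 percentage points higher from compound 1 to compound 2 (beyond the scatter), and a number 17 percentage points lower from compound 2 to compound 3 (beyond the scatter). Compound 1 and compound 3 do not separate, since a number 2 percentage points lower from compound 1 to compound 3 (within the scatter).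

Compound 4 `Cc1nc2c(OCc3ccccc3)cccn2c1Br` takes the step (bromo in place of ethoxymethyl on an aromatic carbon). Among the compounds with values here, no measured step removes the whole side group or puts a halogen directly on the ring carbon. The two steps that bear on it, a number 15 percentage points higher from compound 1 to compound 2 (beyond the scatter) and a number 17 percentage points lower from compound 2 to compound 3 (beyond the scatter), both exchange the group on the saturated chain carbon bound to an aromatic carbon and both move the number by a modest amount, with the ethoxymethyl of compound 2 on the higher side each time. Replacing that group altogether is expected to give a modest drop, a number 15 percentage points lower from compound 2 to compound 4 (beyond the scatter). Compound 4 is therefore estimated at 20%, with a range of 5% to 40%.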

Compound 4, a percentage reported as inhibition, in the whole organism at one dose (the size of the read-out at that dose, not a potency): 63%
Beside the measured number, compound 4's estimate is 43 percentage points below it; measured number outside the range, above it.
By their numbers in this assay, from the lowest: compounds 3 and 1 (each within the scatter of the next); then compound 2; then compound 4.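

Up to compound 2, this position had carried only groups attached through a saturated chain carbon, and none of them gave a high number in this assay. A lone bromo directly on the aromatic carbon next to the ring nitrogen changes that, with a number 28 percentage points higher from compound 2 to compound 4 (beyond the scatter) and a number 43 percentage points higher from compound 1 to compound 4 (beyond the scatter) and also a number 45 percentage points higher from compound 3 to compound 4 (beyond the scatter) so the ethoxymethyl of compound 2 does not mark the upper end for this position. No measurement at hand accounts for the rise.

Going by these compounds, whether it belongs to bromine itself or to any small group placed directly on that carbon stays open, and chloro, an amine or a methoxy group there would separate the two. A read-out at one dose also leaves open how the compounds compare across a range of doses.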